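The compounds below may be only part of what the source reports. "The series", "measured", "known", "first", "only" and "open" are said of these compounds alone.

In a functional assay, read by spectrophotometry, with a stated time of 30 min (on this read-out lower numbers stand for an effect already at smaller amounts and higher numbers for an effect only at larger amounts of compound), compound 1 (`O=C(/C=C/c1ccc(O)c(O)c1)N1CCN(S(=O)(=O)c2cccc3cnccc23)CC1`) gives 9930 nM, compound 2 (`O=C(/C=C/c1ccc(O)c(O)c1)N1CCCN(S(=O)(=O)c2cccc3cnccc23)CC1`) gives 10000 nM and compound 3 (`O=C(CCc1ccc(O)c(O)c1)N1CCCN(S(=O)(=O)c2cccc3cnccc23)CC1`) gives 9680 nM, so compound 3 stands within the scatter of both others. Compound 4 (`COc1cc(/C=C/C(=O)N2CCCN(S(=O)(=O)c3cccc4cnccc34)CC2)ccc1O`) has not been measured. It differs from compound 3 by one exchange, 2-(4-hydroxy-3-methoxyphenyl)ethenyl in place of 2-(3,4-dihydroxyphenyl)ethyl on a carbonyl carbon. Among the measured compounds shown here, one measured step bears on the double bond, namely a 1.0-fold lower number from compound 2 to compound 3 (0.01 log units; within the scatter), which lies within the scatter. For the measured compounds named here, no measured step covers the methoxy group, so that part remains open and the range is kept wide. No shift beyond the scatter is expected, and the expected step is a 1.0-fold higher number from compound 3 to compound 4 (0.01 log units; within the scatter). Compound 4 is estimated at 10000 nM, with an expected range from 5000 nM to 25000 nM.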

Compound 4, half-maximal effective concentration: 9610 nM
Estimate against measurement, compound 4: 1.0-fold (0.02 log units) above; the measured number falls inside the stated range.
By their numbers in this assay, from the lowest: compounds 4, 3, 1 and 2 (each within the scatter of the next).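

Methyl in place of hydrogen on an oxygen on an aromatic ring, the one part not covered before, gives a 1.0-fold lower number from compound 2 to compound 4 (0.02 log units; within the scatter). The full exchange on the carbonyl carbon, which also brings back the double bond, gives a 1.0-fold lower number from compound 3 to compound 4 (0.00 log units; within the scatter), so neither step leaves the scatter and this position shows no sensitivity to these changes. Nothing available offers an explanation for this.

On these data alone, whether any change at this position can shift the number remains open. An amine or a carboxylic acid on the aromatic ring, or a longer chain to the carbonyl, is not among the compounds shown.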